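This account rests on a few compounds, and the source may have more. Where it says the series, first, only, none or still open, it means among the compounds named here.

Measured so far:
- compound 1 `c1cc(CN2CCN(CCCc3c[nH]c4ccc(-n5cnnc5)cc34)CC2)ccn1`: 0.6 nM
- compound 2 `c1coc(CN2CCN(CCCc3c[nH]c4ccc(-n5cnnc5)cc34)CC2)c1`: 0.4 nM
- compound 3 `CC(=O)Nc1ccc(CN2CCN(CCCc3c[nH]c4ccc(-n5cnnc5)cc34)CC2)cc1`: 2.5 nM

In an assay on CHO cells for displacement of a labelled ligand from 5-hydroxytryptamine receptor 1D (Homo sapiens) (a lower number here means a stronger inhibitor, a higher number a weaker inhibitor), compound 1 stands second highest of the three, with compound 2 within the scatter of it and compound 3 a modest distance above it. Compound 4 `CN1CCN(CCCc2c[nH]c3ccc(-n4cnnc4)cc23)CC1` differs from compound 1 in one place: hydrogen in place of pyridin-4-yl on a saturated chain carbon bound to an amine nitrogen in a ring. Among the measured compounds shown here, the steps that bear on this all change the same group: a 1.5-fold lower number from compound 1 to compound 2 (0.18 log units; within the scatter), a 4.2-fold higher number from compound 1 to compound 3 (0.62 log units; beyond the scatter) and a 6.3-fold higher number from compound 2 to compound 3 (0.80 log units; beyond the scatter). Swapping one ring for another leaves the number almost unchanged or raises it modestly; no measured compound lacks the ring altogether, so taking it away is a larger change than any step seen. A modest rise in this assay is therefore expected for compound 4, estimated as an 8.3-fold higher number from compound 1 to compound 4 (0.92 log units; beyond the scatter), giving 5 nM with a likely range of 1.5 nM to 20 nM.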

Compound 4, half-maximal inhibitory concentration: 33 nM
For compound 4 the middle estimate is 6.6-fold (0.82 log units) below the measured one; measured number above the stated range.
By their numbers in this assay, from the lowest: compounds 2 and 1 (each within the scatter of the next); then compound 3; then compound 4.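

In this assay, removing the ring from this position does far more than swapping one ring for another: a 55-fold higher number from compound 1 to compound 4 (1.74 log units; beyond the scatter), an 83-fold higher number from compound 2 to compound 4 (1.92 log units; beyond the scatter) and a 13-fold higher number from compound 3 to compound 4 (1.12 log units; beyond the scatter). Even 4-acetamidophenyl, the ring group with the highest number, stays well clear of compound 4, so the presence of a ring group on this saturated chain carbon counts for more than which ring it is. Nothing available explains this difference. Still open, on these data alone, is whether an aromatic ring is needed here, or whether a cyclohexyl ring or a plain propyl chain on this carbon would serve as well.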